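The source may hold more compounds than are shown below. What is called first, only, known or untested is meant among the compounds shown, and "the series" means these compounds.

In a functional assay on DU-145 cells (Homo sapiens) for inhibition, read by trypan blue exclusion, with a stated time of 96 h (on this read-out lower numbers stand for stronger inhibition of growth and higher numbers for weaker inhibition of growth), compound 2 (`O=C(/C(=C\c1ccc(Br)cc1)S(=O)(=O)c1ccc(Br)cc1)c1ccc(Br)cc1`) gives 10000 nM. Compound 3 (`Cc1ccc(S(=O)(=O)/C(=C/c2ccc(Br)cc2)C(=O)c2ccc(Br)cc2)cc1`) gives 10000 nM, which places it level with compound 2. Compound 1 (`O=C(/C(=C\c1ccc(O)cc1O)S(=O)(=O)c1ccccc1Br)c1ccc(Br)cc1`) gives only a limit, > 100000 nM. Compound 4 (`O=C(/C(=C\c1ccc(Br)cc1)S(=O)(=O)c1ccccc1Br)c1ccc(Br)cc1`) has not yet been measured, and it carries 2-bromophenyl in place of 4-methylphenyl on a sulfonyl sulfur. Among the measured compounds shown here, the one measured step that bears on this change is no change at the digits printed from compound 2 to compound 3 (within the scatter), with methyl in place of bromo on an aromatic carbon. No shift beyond the scatter is therefore expected in this assay, and the expected step is no change at the digits printed from compound 3 to compound 4 (within the scatter). The estimate for compound 4 is 10000 nM, with an expected range of 3000 nM to 40000 nM.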

Compound 4, concentration for 50% growth inhibition: 1000 nM
Beside the measured number, compound 4's estimate is 10-fold (1.00 log units) above it, and the stated range ends above it.
By their numbers in this assay, from the lowest: compound 4; then compounds 2 and 3 (each within the scatter of the next). At a limit, above all of these: compound 1.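

In this assay, the group on the sulfonyl sulfur proves able to move the number: 4-methylphenyl and 4-bromophenyl had stood level, yet 2-bromophenyl gives a 10-fold lower number from compound 3 to compound 4 (1.00 log units; beyond the scatter) and a 10-fold lower number from compound 2 to compound 4 (1.00 log units; beyond the scatter). On the double-bonded chain carbon, 4-bromophenyl in place of 2,4-dihydroxyphenyl gives an at least 100-fold lower number from compound 1 to compound 4 (2.00 log units; beyond the scatter). Compound 1 stands only at a limit, which bounds that step: the limit of > 100000 nM in this assay, at which 1 of the 4 values shown sits.

On these data alone, whether the lower number needs bromine itself remains open, as 2-chlorophenyl or 2-methylphenyl on the sulfonyl sulfur could show. As far as these compounds go, how an amine or a carboxylic acid on that ring would read is also open.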